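Ortho-substituent swap on a bile acid receptor agonist core

The source may hold more compounds than are shown below. What is called first, only, known or untested is meant among the compounds shown, and "the series" means these compounds.

Measured compounds:
compound 1 `Cc1nn(-c2ccccc2I)c2c1C(c1ccc(Oc3ccccc3)cc1)SC(C)C(=O)N2` 130%
compound 2 `Cc1nn(-c2ccccc2Cl)c2c1C(c1ccc(Oc3ccccc3)cc1)SC(C)C(=O)N2` 57%

Two compounds share one core and differ only in the group on the aromatic carbon of the pendant ring. In an assay on isolated protein for agonist activity at Bile acid receptor (Homo sapiens), read by AlphaScreen, with a stated time of 30 min (a lower number here means a smaller maximal response, a higher number a larger maximal response), compound 1 gives 130%. Compound 2, in this assay, gives 57%, the lowest of the two numbers shown; its nearest neighbour is compound 1, and the step of a number 73 percentage points lower from compound 1 to compound 2 (beyond the scatter) is large and beyond the scatter.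

Compound 3 `Cc1nn(-c2ccccc2C(F)(F)F)c2c1C(c1ccc(Oc3ccccc3)cc1)SC(C)C(=O)N2` has not yet been measured in this assay. It differs from compound 2 in one place: trifluoromethyl in place of chloro on an aromatic carbon.

Within the data shown here, only the step from compound 1 to compound 2 bears on this change, and it was large, a number 73 percentage points lower from compound 1 to compound 2 (beyond the scatter). Among the measured compounds shown here, that step replaced a large halogen with a smaller one and the response fell; compound 3 carries a group that is again larger than chloro but is not a halogen, so no measured pair reports the same move. The expected step of a number 28 percentage points higher from compound 2 to compound 3 (beyond the scatter) in this assay is therefore upward but uncertain in size. The estimate for compound 3 in this assay is 85%, with a range from 45% to 130%.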

Compound 3, largest response reached (reported as efficacy), in percent of the reference or control that the assay uses: 50%
Compound 3: the middle estimate sits 35 percentage points above what was measured; the measured number falls inside the stated range.
By their numbers in this assay, from the lowest: compounds 3 and 2 (each within the scatter of the next); then compound 1.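

In this assay, trifluoromethyl and chloro on this aromatic carbon cannot be told apart, the step being a number 7 percentage points lower from compound 2 to compound 3 (within the scatter), so a larger count of heavy atoms in the entering group did not by itself restore the response seen with iodo. Iodo stands alone among the three groups shown, with a number 80 percentage points lower from compound 1 to compound 3 (beyond the scatter), while chloro and trifluoromethyl share one lower level, which means the high response at this position is so far tied to a single compound rather than to a trend across the series. Nothing measured alongside these numbers bears on what lies behind them.

On these data alone, what remains open is whether bromo, methyl, methoxy or a nitrile on this same carbon would reach the level of compound 1 at 130% or stay with compound 3 at 50% in this assay. As far as these compounds go, it is also open whether an amine or a carboxylic acid in this place would give a response of either kind.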